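The source may report more compounds than this note shows. Statements on the series, on what has been measured and on what is new or still open speak of the compounds shown alone.

Values in a functional assay on HT-29 cells (Homo sapiens) for inhibition, read by MTT assay, with a stated time of 72 h; a lower number here means a stronger inhibitor, a higher number a weaker inhibitor:
compound 1 `COc1cc2c(Oc3ccc(NC(=O)c4nn(-c5ccccc5C)c(=O)cc4C)cc3F)ccnc2cc1OCCCN1CCCCC1`, 2810 nM
compound 2 `COc1cc2c(Oc3ccc(NC(=O)c4nn(-c5cccc(F)c5)c(=O)cc4C)cc3F)ccnc2cc1OCCCN1CCCCC1`, 290 nM
compound 3 `COc1ccc(-n2nc(C(=O)Nc3ccc(Oc4ccnc5cc(OCCCN6CCCCC6)c(OC)cc45)c(F)c3)c(C)cc2=O)cc1`, 3200 nM

Compound 3 stands at the highest number of the three: compound 1 sits within the scatter of it, a 1.1-fold higher number from compound 1 to compound 3 (0.06 log units; within the scatter), while compound 2 sits well apart, an 11-fold higher number from compound 2 to compound 3 (1.04 log units; beyond the scatter). Compound 4 `COc1cc2c(Oc3ccc(NC(=O)c4nn(-c5ccc(Cl)cc5Cl)c(=O)cc4C)cc3F)ccnc2cc1OCCCN1CCCCC1` differs from compound 3 in one place: 2,4-dichlorophenyl in place of 4-methoxyphenyl on an aromatic nitrogen. Going by the values given here, two measured steps bear on this. The only halogen-bearing aryl in the set gave the one clear gain, a 9.7-fold lower number from compound 1 to compound 2 (0.99 log units; beyond the scatter), whereas swapping the 2-methylphenyl for the 4-methoxyphenyl changed nothing beyond the scatter, a 1.1-fold higher number from compound 1 to compound 3 (0.06 log units; within the scatter). Compound 4 carries two halogens, one of them in the place that was silent in compound 1, so a lower number than compound 3 is expected but a smaller one than compound 2 achieved, with wide uncertainty. For compound 4 the estimate is 1000 nM, range 250 nM to 4000 nM, i.e. an expected step of a 3.2-fold lower number from compound 3 to compound 4 (0.51 log units; beyond the scatter).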

Compound 4, half-maximal inhibitory concentration: 290 nM
Compound 4: the middle estimate sits 3.4-fold (0.54 log units) above what was measured; the measured number falls inside the stated range.
By their numbers in this assay, from the lowest: compounds 2 and 4 (each within the scatter of the next); then compounds 1 and 3 (each within the scatter of the next).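

In this assay, 2,4-dichlorophenyl on the aromatic nitrogen gives an 11-fold lower number from compound 3 to compound 4 (1.04 log units; beyond the scatter) and a 9.7-fold lower number from compound 1 to compound 4 (0.99 log units; beyond the scatter), so in these four compounds both halogen-bearing aryls sit apart from the two without halogen. The second halogen pattern gives no change at the digits printed from compound 2 to compound 4 (within the scatter), so the gain at this position is not confined to 3-fluorophenyl. Nothing available explains this gain. Going by these compounds, whether a single chlorine would suffice remains open. An aryl carrying an amine or a carboxylic acid, or a cyclohexyl ring on this nitrogen, would test whether halogen is needed at all.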